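Hydrazone aryl swap on a ribosylated aminopurine core

The compounds below may be only part of what the source reports. "The series", "measured", "known", "first", "only" and "open" are said of these compounds alone.

Three hydrazones on the shared core have been measured in an assay on CHO-K1 cells for displacement of a labelled ligand from adenosine receptor A1 (Homo sapiens), read by scintillation counting, with a stated time of 60 min; a lower number here means a stronger inhibitor, a higher number a weaker inhibitor. Compound 2 `Nc1nc(N/N=C/c2ccc(Br)cn2)nc2c1ncn2[C@@H]1O[C@H](CO)[C@@H](O)[C@H]1O` gives 4.7 nM, the lowest of the two numbers obtained. Compound 1 `COc1cc(/C=N/Nc2nc(N)c3ncn([C@@H]4O[C@H](CO)[C@@H](O)[C@H]4O)c3n2)ccc1OCc1ccccc1`, carrying a 3-methoxy-4-benzyloxyphenyl in place of the pyridinyl, gives 9140 nM, far beyond the scatter above compound 2. For compound 3 `Nc1nc(N/N=C/c2ccc(C(F)(F)F)cc2C(F)(F)F)nc2c1ncn2[C@@H]1O[C@H](CO)[C@@H](O)[C@H]1O`, with two trifluoromethyl groups on the phenyl, this assay reports only a limit, > 10000 nM; this is the limit described in the limit of > 10000 nM in this assay, at which 1 of the 3 values shown sits, and not a number.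

For the measured compounds named here, no pair of measured compounds differs in one place, so the step to compound 4 `CN(C)c1ccc(/C=N/Nc2nc(N)c3ncn([C@@H]4O[C@H](CO)[C@@H](O)[C@H]4O)c3n2)cc1` rests on the change itself. Compound 4 differs from compound 2 in 4-(dimethylamino)phenyl in place of 5-bromopyridin-2-yl on a carbon with a double bond to nitrogen. As far as these compounds go, the two phenyl-bearing compounds, compound 1 and compound 3, sit far weaker in this assay than compound 2, which suggests that leaving the pyridinyl costs affinity, though neither carries a dimethylamino group and the direction for this substituent is untested. Compound 4 is expected to be weaker than compound 2 by a step of a 64-fold higher number from compound 2 to compound 4 (1.81 log units; beyond the scatter), beyond the scatter. The estimate for compound 4 in this assay is 300 nM, within a range from 30 nM to 5000 nM.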

Compound 4, inhibition constant: > 10000 nM
Compound 4 gave a limit, no number; the forecaster's own chance of this, stated with the estimate: 10%; middle value at least 33-fold (1.52 log units) from the limit.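

In this assay, for the compounds shown here, 4-(dimethylamino)phenyl in place of 5-bromopyridin-2-yl on a carbon with a double bond to nitrogen gives an at least 2100-fold higher number from compound 2 to compound 4 (3.32 log units; beyond the scatter), the first step that can be read at a single place. The earlier compounds shown here only suggested that this position is sensitive to the aryl group, and this step shows that the swap alone is enough for a large loss, without the 3-methoxy-4-benzyloxyphenyl of compound 1 or the two trifluoromethyl groups of compound 3. Compound 4 gives a limit and not a number, so the step has a floor but no measured size: the limit of > 10000 nM in this assay, at which 2 of the 4 values shown sit.

The step exchanges the ring nitrogen, the bromine and the dimethylamino group all at once, so the data do not show which of these changes accounts for the loss. A pyridinyl without bromine and a bromophenyl without the ring nitrogen would separate these contributions, and the compounds shown include neither group.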